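Swapping methoxy for amino on the weakest measured compound

The source may report more compounds than this note shows. Statements on the series, on what has been measured and on what is new or still open speak of the compounds shown alone.

Among the measured compounds shown here, in a functional assay on HT-29 cells (Homo sapiens) for inhibition, read by MTT assay, with a stated time of 72 h (on this read-out lower numbers stand for stronger inhibition and higher numbers for weaker inhibition), compound 1 `COc1cccc(/C=C/C(=O)Nc2cc(OC)c(OC)c(OC)c2)c1` gives 44100 nM, the highest number of the three measured so far. Compound 2 `C=C(Br)C(=O)Nc1cccc(/C=C/C(=O)Nc2ccccc2)c1` gives 16600 nM, and compound 3 `C=C(Br)C(=O)Nc1cccc(/C=C/C(=O)Nc2ccc(F)c(F)c2)c1` gives 8700 nM. Both differ from compound 1 in several parts of the structure.

Compound 4 `COc1cc(NC(=O)/C=C/c2cccc(N)c2)cc(OC)c1OC` has not yet been measured. It differs from compound 1 by a single change, amino in place of methoxy on an aromatic carbon, meta to a large group.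

For the measured compounds named here, the only measured single change is a 1.9-fold lower number from compound 2 to compound 3 (0.28 log units; within the scatter), with 3,4-difluorophenyl in place of phenyl on an amide-type nitrogen. That step is small and involves different groups, so it offers only a weak guide here. Going by the values given here, no measured step covers the swap from methoxy to amino, so no shift beyond the scatter is expected in this assay.

The expected step is a 1.1-fold lower number from compound 1 to compound 4 (0.04 log units; within the scatter). Compound 4 is estimated at 40000 nM, with an expected range from 13000 nM to 100000 nM.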

Compound 4, half-maximal inhibitory concentration: 63100 nM
Compound 4: the middle estimate sits 1.6-fold (0.20 log units) below what was measured, within the range that was stated.
By their numbers in this assay, from the lowest: compounds 3 and 2 (each within the scatter of the next); then compounds 1 and 4 (each within the scatter of the next).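

In this assay amino in place of methoxy on an aromatic carbon, meta to a large group, gives a 1.4-fold higher number from compound 1 to compound 4 (0.16 log units; within the scatter) and so does not separate the two compounds beyond the usual scatter. This is the first step shown at this position, and 3-methoxyphenyl and 3-aminophenyl cannot be told apart here, even though amino carries a hydrogen-bond donor and methoxy carries none. No measurement available here bears on the reason for this result.

Going by these compounds, whether another group at this position, such as hydroxyl, fluorine or dimethylamino, would give a step beyond the scatter stays open. Among the compounds shown here, also open is whether the swap would read the same on a different core, as only this one pair of compounds carries it.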